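Replacing methyl with tert-butyl in compound 2

The compounds below may be only part of what the source reports. "The series", "measured", "known", "first", "only" and "open" are said of these compounds alone.

Among the measured compounds shown here, in a functional assay on SK-OV-3 cells (Homo sapiens) for antiproliferative activity, read by MTT assay, with a stated time of 72 h (a higher number here means a weaker inhibitor, a lower number a stronger inhibitor), compound 2 `Cc1ccc(NC(=O)CCc2cccc3c2B(O)OC3)cc1` gives 860 nM, the lower of the two numbers so far, and compound 1 `O=C(CCc1cccc2c1B(O)OC2)Nc1ccc(Cl)cc1` gives 5000 nM. Compound 3 `CC(C)(C)c1ccc(NC(=O)CCc2cccc3c2B(O)OC3)cc1` carries tert-butyl in place of methyl on an aromatic carbon. For the measured compounds named here, the only measured step that bears on this change, methyl in place of chloro, is a 5.8-fold lower number from compound 1 to compound 2 (0.76 log units; beyond the scatter), modest and beyond the scatter. That single step fixes no direction for tert-butyl, so only a small shift is expected, a 1.1-fold lower number from compound 2 to compound 3 (0.06 log units; within the scatter), possibly none beyond the scatter. Compound 3 is estimated at 750 nM, with an expected range of 250 nM to 2500 nM.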

Compound 3, half-maximal inhibitory concentration: 4200 nM
Compound 3: the middle estimate sits 5.6-fold (0.75 log units) below what was measured; the whole stated range lies below it.
By their numbers in this assay, from the lowest: compound 2; then compounds 3 and 1 (each within the scatter of the next).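

At this position, para to a large group, the larger tert-butyl does not keep the number that methyl gives in this assay (a 4.9-fold higher number from compound 2 to compound 3 (0.69 log units; beyond the scatter)). Tert-butyl instead lands level with chloro (a 1.2-fold lower number from compound 1 to compound 3 (0.08 log units; within the scatter)). Among these three groups, methyl alone stands apart, and compound 2 remains the only compound with a clearly lower number. No evidence is available to explain this result. As far as these compounds go, whether ethyl or isopropyl would stay close to methyl or fall with tert-butyl remains open, as does the effect of a methoxy group or an amine here.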